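The source may report more compounds than this note shows. Statements on the series, on what has been measured and on what is new or still open speak of the compounds shown alone.

Measured compounds:
Compound 2, `Nc1cc(N)c2nc(-c3ccccc3)c(NCc3ccc(F)cc3)nc2c1`: 2000 nM
Compound 1, `Nc1cc(N)c2nc(-c3ccccc3)c(NCc3ccc(Cl)c(Cl)c3)nc2c1`: 2750 nM
Compound 3, `COc1ccc(CNc2nc3cc(N)cc(N)c3nc2-c2ccccc2)cc1`: 10000 nM

All three were tested in a functional assay on MDA-MB-435 cells (Homo sapiens) for inhibition, read by sulforhodamine B assay, with a stated time of 48 h; on this read-out higher numbers stand for weaker inhibition of growth and lower numbers for stronger inhibition of growth. Within the data shown here, compound 2 shows the lowest of the three numbers, though the gap a 1.4-fold lower number from compound 1 to compound 2 (0.14 log units; within the scatter) lies within the scatter; only the step of a 5.0-fold higher number from compound 2 to compound 3 (0.70 log units; beyond the scatter) lies beyond it. Compound 4, `Nc1cc(N)c2nc(-c3ccccc3)c(Oc3ccc(F)cc3)nc2c1`, alters the link between the shared core and the fluorinated ring: 4-fluorophenoxy in place of (4-fluorobenzyl)amino on an aromatic carbon. Neither measured step touches that link; both only exchange the group on the outer ring, so no step size can be read from them for this change. A modest weakening in this assay is expected, a 2.0-fold higher number from compound 2 to compound 4 (0.30 log units; within the scatter), with wide uncertainty. For compound 4 the expected value is 4000 nM, in a range from 1000 nM to 20000 nM.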

Compound 4, concentration for 50% growth inhibition: 15800 nM
The estimate for compound 4 lay 4.0-fold (0.60 log units) below the measured number; the measured number falls inside the stated range.
By their numbers in this assay, from the lowest: compounds 2 and 1 (each within the scatter of the next); then compounds 3 and 4 (each within the scatter of the next).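

Among these compounds, the link to the shared core changes here for the first time, and in this assay the step of a 7.9-fold higher number from compound 2 to compound 4 (0.90 log units; beyond the scatter) lies beyond the scatter. This position therefore responds to the link itself, not only to the group on the outer ring, with 4-fluorophenoxy giving weaker growth inhibition than (4-fluorobenzyl)amino. No measurement shown here explains this step.

As far as these compounds go, the change removes the nitrogen and the saturated chain carbon together, so their separate contributions remain unknown. A 4-fluorobenzyloxy or 4-fluoroanilino group at this position could help separate them.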